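From a Methoxyphenyl Ether to a Chlorophenyl Ether

The compounds below may be only part of what the source reports. "The series", "measured", "known", "first", "only" and "open" are said of these compounds alone.

Of the compounds shown here, three built on a shared core have been measured in an in vitro assay on SH-SY5Y cells for displacement of a labelled ligand from Neuronal acetylcholine receptor; alpha3/beta4 (Homo sapiens); on this read-out higher numbers stand for weaker inhibition and lower numbers for stronger inhibition. Compound 1 `COc1ccccc1Oc1cncc(C2=CC3CNCC(C2)C3)c1` gives 56 nM. Compound 2 `CC(C)Oc1cncc(C2=CC3CNCC(C2)C3)c1` gives 4.8 nM in this assay, and compound 3 `COc1cccc(Oc2cncc(C3=CC4CNCC(C3)C4)c2)c1` gives 15 nM. Among these three numbers compound 3 stands second highest: the step of a 3.1-fold higher number from compound 2 to compound 3 (0.49 log units; beyond the scatter) separates it from compound 2, while the step of a 3.7-fold lower number from compound 1 to compound 3 (0.57 log units; beyond the scatter) sets it apart from compound 1.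

Compound 4 `Clc1ccccc1Oc1cncc(C2=CC3CNCC(C2)C3)c1` has not yet been measured. It differs from compound 3 in one place: 2-chlorophenyl in place of 3-methoxyphenyl on an oxygen on an aromatic ring. The measured step that bears most on this change is a 3.7-fold lower number from compound 1 to compound 3 (0.57 log units; beyond the scatter), in which a 2-methoxyphenyl was exchanged for a 3-methoxyphenyl and the number fell. Compound 4 goes back to a phenyl carrying its substituent at the 2-position of that name, now a 2-chlorophenyl, so a step in the opposite direction seems likely. Among the compounds with values here, no measured pair compares a chlorine with a methoxy group on this phenyl, so the size remains uncertain. The writer therefore expects a modestly higher number for compound 4, a step of a 2.3-fold higher number from compound 3 to compound 4 (0.37 log units; beyond the scatter), and estimates compound 4 at about 35 nM, within a range from 12 nM to 100 nM.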

Compound 4, inhibition constant: 26 nM
Compound 4: middle estimate off by 1.3-fold (0.13 log units), on the high side; low and high end bracket the measured number.
By their numbers in this assay, from the lowest: compound 2; then compounds 3 and 4 (each within the scatter of the next); then compound 1.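

Chloro in place of methoxy on the same phenyl gives a 2.2-fold lower number from compound 1 to compound 4 (0.33 log units; beyond the scatter) in this assay, the first measured change of the substituent itself rather than of the whole group on this oxygen, and it shows that the number here depends on that substituent as well. The exchange of 3-methoxyphenyl for 2-chlorophenyl gives a 1.7-fold higher number from compound 3 to compound 4 (0.24 log units; within the scatter), so this pair cannot be separated in this assay, although the 3-methoxyphenyl of compound 3 was clearly separated from the 2-methoxyphenyl of compound 1. The isopropyl group keeps its distance from this new phenyl ether as well, with a 5.4-fold higher number from compound 2 to compound 4 (0.73 log units; beyond the scatter), so among the four compounds all three substituted phenyl groups on this oxygen give higher numbers than isopropyl.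

The compounds shown leave open how an unsubstituted phenyl or a cyclopentyl group on this oxygen would read in this assay, and so whether the substituent on the phenyl or the phenyl itself accounts for most of the distance from compound 2. Nothing given here offers an explanation for any of these steps.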